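The compounds below may be only part of what the source reports. "The series", "measured", "known", "first", "only" and "open" are said of these compounds alone.

In a functional assay on NCI-H1299 cells (Homo sapiens) for inhibition, with a stated time of 48 h, at 37 degrees C (a higher number here means a weaker inhibitor of growth, a lower number a stronger inhibitor of growth), compound 1 `Clc1ccc(-c2noc(-c3occc3Cl)n2)cc1` gives > 10000 nM, which is a limit of the assay and not a number. Compound 2 `FC(F)(F)c1ccc(-c2noc(-c3occc3Br)n2)cc1` also reaches only a limit, > 10000 nM, so it has no exact value. The data so far show (the limit of > 10000 nM in this assay, at which 2 of the 2 values shown sit). Compound 3 `FC(F)(F)c1ccc(-c2noc(-c3occc3Cl)n2)cc1` differs from compound 2 at a single place: chloro in place of bromo on an aromatic carbon. Among the compounds with values here, no measured step shows the effect of this swap. The expected step that the limit leaves unreadable from compound 2 to compound 3 is estimated to stay within the usual scatter. Compound 3 is expected to give about 12000 nM, with an estimated range from 4000 nM to 30000 nM.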

Compound 3, concentration for 50% growth inhibition: > 10000 nM
Compound 3: no number, only a limit (the forecaster's own chance of this, stated with the estimate: 70%); the middle value lies beyond the limit too.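

Within the data shown here, compound 1, compound 2 and compound 3 all stop at a limit and not at a number, so no step between them can be read: the limit of > 10000 nM in this assay, at which 3 of the 3 values shown sit. As far as these compounds go, whether chloro in place of bromo, or trifluoromethyl in place of chloro, changes growth inhibition at all stays open.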